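A few compounds are considered here, and "the series" means these few. Any claim that something is new, unique, unknown or untested is made for them only; others in the source may bear on it.

Compound 1 `NS(=O)(=O)c1ccc(Nc2nc(N/N=C/c3ccc(C(F)(F)F)cc3)nc(Nc3ccccc3)n2)cc1` gives 3450 nM in a functional assay on TK-10 cells (Homo sapiens) for inhibition, read by sulforhodamine B assay, with a stated time of 48 h; a higher number here means a weaker inhibitor of growth, a lower number a stronger inhibitor of growth.
Compound 2 `Cc1nn(-c2ccccc2)cc1/C=N/Nc1nc(Nc2ccccc2)nc(Nc2ccc(S(N)(=O)=O)cc2)n1` gives 1480 nM in this assay.

Of the two numbers shown, compound 2 has the lowest; its nearest neighbour is compound 1, with a 2.3-fold lower number from compound 1 to compound 2 (0.37 log units; beyond the scatter), a change of the group on the carbon with a double bond to nitrogen. Compound 3 `NS(=O)(=O)c1ccc(Nc2nc(N/N=C/c3ccccn3)nc(Nc3ccccc3)n2)cc1` differs from compound 2 at that same place: pyridin-2-yl in place of 3-methyl-1-phenyl-1H-pyrazol-4-yl on a carbon with a double bond to nitrogen. Among the measured compounds shown here, only that one measured step bears on this change, and it shows that exchanging the group on that carbon can move this assay modestly; it does not show what pyridin-2-yl does there. Nothing further is known about the group that enters. The change is therefore expected to be small, most likely a somewhat higher number, close to the scatter: a 1.7-fold higher number from compound 2 to compound 3 (0.23 log units; within the scatter). Compound 3 is estimated at 2500 nM in this assay, within a range from 900 nM to 7000 nM.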

Compound 3, concentration for 50% growth inhibition: 1190 nM
Compound 3: the middle estimate sits 2.1-fold (0.32 log units) above what was measured, and the stated range covers the measured number.
By their numbers in this assay, from the lowest: compounds 3 and 2 (each within the scatter of the next); then compound 1.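

At the carbon with a double bond to nitrogen, a much smaller group serves as well as the larger one in this assay: pyridin-2-yl, with fewer heavy atoms, replaces 3-methyl-1-phenyl-1H-pyrazol-4-yl in a 1.2-fold lower number from compound 2 to compound 3 (0.09 log units; within the scatter). Set against 4-(trifluoromethyl)phenyl, pyridin-2-yl gives a 2.9-fold lower number from compound 1 to compound 3 (0.46 log units; beyond the scatter), so two different nitrogen-containing aromatic groups now stand on the same side of compound 1 by a modest margin. No measurement here accounts for either step.

The compounds shown leave open whether the ring nitrogen of pyridin-2-yl matters, which plain phenyl or pyridin-4-yl at this carbon would test. They also leave open whether this carbon needs an aromatic ring at all, as a short alkyl chain or a carboxylic acid there would show.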